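This account rests on a few compounds, and the source may have more. Where it says the series, first, only, none or still open, it means among the compounds named here.

Measured compounds:
- Compound 1 `Fc1ccc(-c2nn3c(NC4CCCC4)cccc3c2-c2ccoc2)cc1`: in an ADME assay on Vero cells (Chlorocebus sabaeus) for cytotoxicity (a higher number here means that more compound is tolerated, a lower number that less compound is tolerated), compound 1 gives "not determined" (no result reported)
- Compound 2 `Nc1nccc(-c2c(-c3ccc(F)cc3)nn3c(NC4CCCC4)cccc23)n1`: in this assay compound 2 gives 46000 nM

Among the compounds with values here, compound 2 is the only compound with a number here; compound 1 shares the core but was left without a result, so nothing can be compared across it. Compound 2 therefore stands alone, and its value is the sole anchor for what follows.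

Compound 3 `Fc1ccc(-c2nn3c(NC4CCCC4)cccc3c2-c2cccnc2)cc1` is the next compound. Its change from compound 2 is pyridin-3-yl in place of 2-aminopyrimidin-4-yl on an aromatic carbon. The shared core and the 4-fluorophenyl group stay in place; only the six-membered ring on the five-membered ring is exchanged.

Within the data shown here, no step between measured compounds exists to show how such an exchange plays out in this assay. Among the measured compounds shown here, with the single value of compound 2 as the only guide, a step no larger than the usual scatter is expected, with no clear direction. On that basis compound 3 is expected to give 40000 nM, within a range from 15000 nM to 100000 nM, which corresponds to a step of a 1.2-fold lower number from compound 2 to compound 3 (0.06 log units; within the scatter) that is estimated to stay inside the scatter.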

Compound 3, half-maximal cytotoxic concentration: > 40000 nM
Compound 3 was reported as a limit; the forecaster's own chance of this, stated with the estimate: 30%; the middle value lies on the limit itself.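

In this assay compound 3 gives > 40000 nM, which is a limit and not a number. The step from compound 2 to compound 3 cannot be read, because the result for compound 3 is only this: the limit of > 40000 nM in this assay, at which 1 of the 3 values shown sits.

The compounds shown leave open what pyridin-3-yl in place of 2-aminopyrimidin-4-yl does in this assay.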